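A few compounds are considered here, and "the series" means these few. Any claim that something is new, unique, unknown or untested is made for them only; others in the source may bear on it.

Measured so far:
- compound 1, `CC(=O)c1ccc(NCc2cncn2Cc2ccc(-c3ccccc3)cc2)cc1-c1ccccc1`: > 10000 nM
- compound 2, `COC(=O)c1ccc(NCc2cncn2Cc2ccc(N)cc2)cc1-c1ccccc1`: > 10000 nM

Both entries in a toxicity assay on NIH3T3 cells (Mus musculus) for cytotoxicity, read by resazurin assay (a higher number here means that more compound is needed for the effect, a lower number that less compound is needed), are limits of the assay rather than numbers; (the limit of > 10000 nM in this assay, at which 2 of the 2 values shown sit). Compound 2 stands at that limit in this assay. Among the measured compounds shown here, the one other value shown, for compound 1, is the same limit. Nothing can therefore be said about an order between the two, only that neither showed an effect within the tested range.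

Compound 3, `COC(=O)c1ccc(NCc2cncn2Cc2ccc(Br)cc2)cc1-c1ccccc1`, is the next member. Its change from compound 2 is bromo in place of amino on an aromatic carbon. For the measured compounds named here, no step between measured compounds is available for this change, and the two limits give no trend to build on. The expectation is that the step from compound 2 to compound 3 in this assay stays within the usual scatter, written as a step that the limit leaves unreadable from compound 2 to compound 3. Compound 3 is thus estimated at 20000 nM in this assay, with a range from 7000 nM to 60000 nM, most likely again reported only as a limit.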

Compound 3, half-maximal effective concentration: > 10000 nM
Compound 3 was reported as a limit; the forecaster's own chance of this, stated with the estimate: 75%; the middle value does not contradict the limit.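

Among the compounds shown here, no step from compound 2 to compound 3 can be read in this assay, as both results are limits of the assay and not numbers: the limit of > 10000 nM in this assay, at which 3 of the 3 values shown sit.

The compounds shown leave open whether any member of the series has an effect within the tested range, and how bromo and amino would compare in this assay.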